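This account rests on a few compounds, and the source may have more. Where it says the series, first, only, none or still open, it means among the compounds named here.

For the measured compounds named here, in a functional assay for inhibition, with Homo sapiens as the target (a lower number here means a stronger inhibitor, a higher number a weaker inhibitor), only two compounds have numbers so far. Compound 1 (`CC(=O)Nc1ccc(Nc2nccc(-c3cccnc3)n2)cc1`) gives 3600 nM in this test, and compound 2 (`CC1CCN(c2ccc(Nc3nccc(-c4ccccn4)n3)cc2)CC1`) gives 1900 nM in the same test. These two numbers lie within the usual scatter of repeated measurements, so compound 2 cannot be ranked ahead of compound 1.

Compound 3 (`CC1CCN(c2ccc(Nc3nccc(-c4cccnc4)n3)cc2)CC1`) has not been measured yet. The change from compound 2 is pyridin-3-yl in place of pyridin-2-yl on an aromatic carbon and amounts to pyridin-3-yl in place of pyridin-2-yl on an aromatic carbon. The two compounds therefore have the same atoms, joined differently.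

Going by the values given here, no measured pair shows this swap on its own, so the data give no direct guide to its effect in this assay and any forecast must stay loose. The natural starting point is compound 2 at 1900 nM as the closest measured structure. The expected step of a 1.1-fold higher number from compound 2 to compound 3 (0.02 log units; within the scatter) is an estimate that stays within the scatter, with no firm direction. The estimate for compound 3 is 2000 nM with an expected range from 650 nM to 6000 nM once it is measured.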

Compound 3, half-maximal inhibitory concentration: 500 nM
For compound 3 the middle estimate is 4.0-fold (0.60 log units) above the measured one; measured number outside the range, below it.
By their numbers in this assay, from the lowest: compound 3; then compounds 2 and 1 (each within the scatter of the next).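

In this assay, putting pyridin-3-yl in place of pyridin-2-yl gives a 3.8-fold lower number from compound 2 to compound 3 (0.58 log units; beyond the scatter), which is beyond the scatter even though the two groups have the same atoms, joined differently, so the way this ring is attached to the shared core clearly matters. For the compounds shown here, with pyridin-3-yl held constant, 4-methylpiperidin-1-yl in place of acetamido gives a 7.2-fold lower number from compound 1 to compound 3 (0.86 log units; beyond the scatter), also beyond the scatter; this is the first clean reading of that second site. Compound 1 and compound 2 could not provide it, as they differ in two places. Nothing measured here explains why either change lowers the number.

On these data alone, the pyridine site has only two forms to compare, so it remains open whether pyridin-4-yl or a plain phenyl ring would fit the same trend, and whether the step seen between the two pyridines would keep its size alongside acetamido. At the other site, a single swap cannot show which part of 4-methylpiperidin-1-yl matters, and a morpholine, a piperazine or an unsubstituted piperidine would help to separate the ring from its methyl group.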